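Replacing a Carbamate with a Pentyl Chain on a Cytotoxic Core

This account rests on a few compounds, and the source may have more. Where it says the series, first, only, none or still open, it means among the compounds named here.

Of the compounds shown here, three sharing a bicyclic core have been tested in a functional assay on WI-38 VA13 cells (Homo sapiens) for cytotoxicity; a lower number here means that less compound is needed, a higher number that more compound is needed for the effect. Compound 1, `O=C(Nc1ccc2nc(NC(=O)C3CCCCC3)sc2c1)c1ccc(Cl)cc1Cl`, gives only a limit in this assay, > 4 ug/mL, rather than a number. Compound 2, `O=C(Nc1nc2ccc(N/C(S)=N/C3=CC4OCCOC4C=C3)cc2s1)C1CCCCC1`, gives 1.6 ug/mL. Compound 3, `CC(C)OC(=O)Nc1nc2ccc(NC(=O)c3c(Cl)cccc3Cl)cc2s1`, gives 0.0026 ug/mL in this assay, the lower of the two numbers, and its gap to compound 2 lies well beyond the usual scatter.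

The next compound, compound 4, `CCCCCNc1nc2ccc(NC(=O)c3c(Cl)cccc3Cl)cc2s1`, has not yet been measured. It differs from compound 3 in one place: pentyl in place of isopropoxycarbonyl on a nitrogen on an aromatic ring. An isopropoxycarbonyl group with two hydrogen-bond acceptors gives way to a plain pentyl chain with none, on the nitrogen attached to the aromatic ring.

Within the data shown here, no measured pair shows this kind of exchange, so the direction rests on the spread already seen: compound 3 stands far apart from compound 2, and the weakest change here need not be small. The step from compound 3 to compound 4 in this assay is expected to be upward, a 38-fold higher number from compound 3 to compound 4 (1.59 log units; beyond the scatter), meaning more compound 4 is needed. Compound 4 is therefore estimated to give about 0.1 ug/mL, within a range from 0.005 ug/mL to 2 ug/mL.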

Compound 4, half-maximal effective concentration: 0.27 ug/mL
Estimate against measurement, compound 4: 2.7-fold (0.43 log units) below; the measured number falls inside the stated range.
By their numbers in this assay, from the lowest: compound 3; then compound 4; then compound 2. At a limit, above all of these: compound 1.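

Among these compounds, this pair gives the first clean reading of a single change in this set: in this assay, pentyl in place of isopropoxycarbonyl on the nitrogen gives a 100-fold higher number from compound 3 to compound 4 (2.02 log units; beyond the scatter). The group on this nitrogen is therefore no bystander, although compound 4 still gives a number and not a limit. The exchange removes the carbonyl, the oxygens and the hydrogen-bond acceptors all at once, so this one pair cannot show which of these parts matters, and no measurement shown here gives a reason for the size of the step.

The compounds shown leave open whether an acetyl group, which would keep a carbonyl on this nitrogen without the isopropyl part, would stay close to compound 3, and whether a butyl or a hexyl chain would differ from the pentyl chain of compound 4. They also leave open whether the step would hold if a plain benzoyl group replaced the dichlorinated benzoyl group that compound 3 and compound 4 share.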